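Trimming a piperidine to a dimethylamine on the aryl amide

The compounds below may be only part of what the source reports. "The series", "measured", "known", "first", "only" and "open" are said of these compounds alone.

Compound 1 `COc1cc(OC)c(Cl)c(-c2ccc3c(NC(=O)c4ccc(N5CCCCC5)cc4)n[nH]c3n2)c1Cl` gives 558 nM in a functional assay on NCI-H1581 cells (Homo sapiens) for antiproliferative activity, read by CCK-8 assay, with a stated time of 72 h (on this read-out higher numbers stand for weaker inhibition and lower numbers for stronger inhibition), the highest of the three numbers in hand. Compound 2 `COc1cc(OC)c(Cl)c(-c2ccc3c(NC(=O)c4ccc(N5CCN(C)CC5)cc4)n[nH]c3c2)c1Cl` gives 324 nM in this assay, a number that lies within the scatter of compound 1. Compound 3 `COc1cc(OC)c(Cl)c(-c2ccc3c(NC(=O)c4ccc(N5CCN(C)CC5)cc4Cl)n[nH]c3n2)c1Cl` gives 27.6 nM in this assay, a lower number than compound 1 and beyond the scatter. Compound 4 `COc1cc(OC)c(Cl)c(-c2ccc3c(NC(=O)c4ccc(N(C)C)cc4)n[nH]c3n2)c1Cl` differs from compound 1 in a single place: dimethylamino in place of piperidin-1-yl on an aromatic carbon. Going by the values given here, no measured pair shows this change on its own, so no step for it is known. Compound 4 is expected to land close to compound 1, with the step of a 1.3-fold higher number from compound 1 to compound 4 (0.10 log units; within the scatter) expected to be small and not beyond the scatter. Compound 4 is therefore estimated at 700 nM, within a range from 250 nM to 2000 nM.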

Compound 4, half-maximal inhibitory concentration: 294 nM
For compound 4 the middle estimate is 2.4-fold (0.38 log units) above the measured one; the range from low to high includes it.
By their numbers in this assay, from the lowest: compound 3; then compounds 4, 2 and 1 (each within the scatter of the next).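

The swap of piperidin-1-yl for dimethylamino can now be read directly in this assay: a 1.9-fold lower number from compound 1 to compound 4 (0.28 log units; within the scatter). This step lies within the scatter, so on this aromatic carbon the six-membered ring of piperidin-1-yl can give way to the smaller, ring-free dimethylamino group without a measurable difference in this read-out. Nothing in hand offers an explanation for this result. Open, going by these compounds, is whether a primary amine, morpholin-4-yl or diethylamino on the same carbon would stay within the scatter of compound 1. On these data alone, a carboxylic acid there is equally open.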